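Shortening the sulfonamide chain on the indane-type core of compound 1

The source may hold more compounds than are shown below. What is called first, only, known or untested is meant among the compounds shown, and "the series" means these compounds.

Compound 1 `CCCS(=O)(=O)Nc1cccc2c1CCC2c1ncc[nH]1` is examined in a functional assay on CHO cells for agonist activity at Alpha-1A adrenergic receptor (Homo sapiens), read by FLIPR and calcium flux (a higher number here means a larger maximal response, a lower number a smaller maximal response), where compound 1 gives 54%. Compound 2 `Cc1c(OCC2=NCCN2)ccc(Cl)c1NS(C)(=O)=O` gives 60% in this assay, a value within the scatter of that of compound 1, so the two cannot be separated. Compound 3 `CCS(=O)(=O)Nc1cccc(Cc2c[nH]cn2)c1` reaches 96% in this assay, beyond the scatter above compound 1. Among the compounds with values here, no pair differing in a single place has been measured, so no step size is known. Compound 4 `CS(=O)(=O)Nc1cccc2c1CCC2c1ncc[nH]1` differs from compound 1 by hydrogen in place of ethyl on a saturated chain carbon bound to a sulfonyl sulfur. A step of this kind is expected to stay within the scatter, in either direction, for compound 4. The maximal response of compound 4 in this assay is estimated at 57%, between 38% and 78%, corresponding to an expected step of a number 3 percentage points higher from compound 1 to compound 4 (within the scatter).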

Compound 4, largest response reached (Emax), in percent of the reference or control that the assay uses: 87%
Compound 4: middle estimate off by 30 percentage points, on the low side; the whole stated range lies below it.
By their numbers in this assay, from the lowest: compounds 1 and 2 (each within the scatter of the next); then compounds 4 and 3 (each within the scatter of the next).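

Replacing propylsulfonyl with methylsulfonyl on the shared core gives a number 33 percentage points higher from compound 1 to compound 4 (beyond the scatter) in this assay. Within the data shown here, this is the first step that differs in one place, and it shows that the chain on the sulfonyl sulfur can by itself shift the maximal response on this core. Nothing available explains why the response moves with this change.

From the compounds shown here alone, it remains open whether an ethyl chain at this place would give an intermediate response, or whether the response depends on chain length at all. Going by these compounds, a cyclopropyl or trifluoromethyl group on the sulfonyl sulfur is also open.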